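The source may hold more compounds than are shown below. What is called first, only, known or untested is meant among the compounds shown, and "the series" means these compounds.

Compound 2 `OC[C@H]1O[C@@H](n2cnc3c(NCc4ccco4)ncnc32)[C@H](O)[C@@H]1O` sits second highest of the three numbers recorded in an assay on isolated protein for binding affinity to Equilibrative nucleoside transporter 1 (Homo sapiens) (on this read-out higher numbers stand for weaker inhibition and lower numbers for stronger inhibition), where compound 2 gives 36300 nM. Its nearest neighbour is compound 3 `CSc1nc(N)nc2c1ncn2[C@@H]1O[C@H](CO)[C@@H](O)[C@H]1O`, which in this assay gives 204000 nM, a weaker result that lies beyond the scatter. Furthest from it stands compound 1 `O=[N+]([O-])c1cccc2c1CCN(c1ncnc3c1ncn3[C@@H]1O[C@H](CO)[C@@H](O)[C@H]1O)C2`, which in this assay gives 3020 nM, a stronger result, again beyond the scatter. No pair among these three differs in a single place, so no measured step exists to lean on.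

Compound 4 `OC[C@H]1O[C@@H](n2cnc3c(CSc4cccc(Cl)c4)ncnc32)[C@H](O)[C@@H]1O` is the untested case. It differs from compound 2 in that (a group of 9 heavy atoms (7 carbon, 1 sulfur, 1 chlorine; one six-membered aromatic ring of carbon only) in place of a group of 7 heavy atoms (5 carbon, 1 nitrogen, 1 oxygen; one five-membered aromatic ring with 1 hetero atom), on an aromatic carbon). Within the data shown here, the group that leaves and the group that enters share nothing but their attachment to the same aromatic carbon, so nothing among the measured compounds fixes the size of the change. Compound 4 is expected to land somewhat below compound 2, with the estimated step of a 3.6-fold lower number from compound 2 to compound 4 (0.56 log units; beyond the scatter) lying beyond the scatter but modest. For compound 4 the estimated value in this assay is 10000 nM, expected to fall between 2000 nM and 50000 nM.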

Compound 4, half-maximal inhibitory concentration: 282 nM
The estimate for compound 4 lay 35-fold (1.55 log units) above the measured number, and the stated range ends above it.
By their numbers in this assay, from the lowest: compound 4; then compound 1; then compound 2; then compound 3.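

In this assay, replacing ((furan-2-yl)methyl)amino with the group carrying sulfur, chlorine and a six-membered aromatic ring of carbon only gives a 130-fold lower number from compound 2 to compound 4 (2.11 log units; beyond the scatter). Among these compounds, this is the first single-place step available, and its size shows that the group on this aromatic carbon, next to the ring nitrogen, can strongly shift the read-out. Nothing available accounts for the size of this step.

The ring, the linking atoms and the chlorine all change together, so the compounds shown do not reveal which of them carries the step. On these data alone, it also remains open whether a benzylamino group, an oxygen in place of the sulfur, or the same group without its chlorine would keep the lower number.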